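The source may report more compounds than this note shows. Statements on the series, on what has been measured and on what is new or still open speak of the compounds shown alone.

Working notes on the series. The read-out throughout is a functional assay on NCI-H1975 cells (Homo sapiens) for antiproliferative activity, read by MTT assay, with a stated time of 72 h; a higher number here means a weaker inhibitor, a lower number a stronger inhibitor. Compound 1, `COc1cc2ncnc(Nc3ccc(F)cc3)c2cc1OCCCCC(=O)Nc1ccc(S(N)(=O)=O)cc1`, reaches only the limit of this assay, > 40000 nM, which is a limit and not a number (the limit of > 40000 nM in this assay, at which 1 of the 3 values shown sits). Compound 2, `COc1ccccc1Nc1ncnc2cc(OC)c(OCCCCC(=O)Nc3ccc(S(N)(=O)=O)cc3)cc12`, gives 8030 nM in this assay, so that the change an at least 4.9-fold lower number from compound 1 to compound 2 (0.69 log units; beyond the scatter) is recorded on a nitrogen on an aromatic ring. Compound 3, `NS(=O)(=O)c1ccc(NC(=S)Nc2ccc3ncnc(Nc4ccc(F)c(Cl)c4)c3c2)cc1`, gives 15800 nM in this assay; its value and that of compound 2 lie within the usual scatter of each other, so compound 3 stands among the two numbers without a separation that can be called real.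

Compound 4, `C#Cc1cccc(Nc2ncnc3ccc(NC(=S)Nc4ccc(S(N)(=O)=O)cc4)cc23)c1`, differs from compound 3 by 3-ethynylphenyl in place of 3-chloro-4-fluorophenyl on a nitrogen on an aromatic ring. For the measured compounds named here, the only measured step that bears on it is the exchange of one aryl group for another on the same kind of nitrogen, the step from compound 1 to compound 2, which was at least modest; no measured pair shows the ethynylphenyl group itself. A step of at most modest size is therefore expected in this assay, with the direction uncertain and a lower number slightly favoured. Compound 4 is estimated at 9000 nM, within 3000 nM to 30000 nM. The expected step is a 1.8-fold lower number from compound 3 to compound 4 (0.24 log units; within the scatter).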

Compound 4, half-maximal inhibitory concentration: 13400 nM
Compound 4: middle estimate off by 1.5-fold (0.17 log units), on the low side; the range from low to high includes it.
By their numbers in this assay, from the lowest: compounds 2, 4 and 3 (each within the scatter of the next). At a limit, above all of these: compound 1.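

In this assay, the exchange of 3-chloro-4-fluorophenyl for 3-ethynylphenyl on a nitrogen on an aromatic ring gives a 1.2-fold lower number from compound 3 to compound 4 (0.07 log units; within the scatter), so at this position, on the core of compound 3, the two aryl groups cannot be told apart, although the chlorine and fluorine are gone and a triple bond has entered. For the compounds shown here, the only earlier aryl exchange on this kind of nitrogen, an at least 4.9-fold lower number from compound 1 to compound 2 (0.69 log units; beyond the scatter), lies beyond the scatter, but it starts from a limit rather than a number and sits on a different compound pair, so it shows only that such an exchange can register in one pair and not in another. Nothing measured here accounts for the lack of a separation between compound 3 and compound 4.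

Still open, as far as these compounds go, is how an amine, a carboxylic acid or a longer chain in place of the aryl group on this nitrogen would read in this assay. Also open, from the compounds shown here alone, is whether 3-ethynylphenyl would read the same on the core of compound 2, whose side chain differs from that of compound 3 and compound 4.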